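The source may hold more compounds than are shown below. What is called first, only, known or untested is meant among the compounds shown, and "the series" means these compounds.

Measured compounds:
- compound 1, `CC(C)N(Cc1cccc(OCCCCCC(=O)O)c1)C(=O)c1ccccc1`: > 26000 nM
- compound 2, `CCCNCc1ccccc1OCCCCCC(=O)OCC`: > 26000 nM

Compound 1, `CC(C)N(Cc1cccc(OCCCCCC(=O)O)c1)C(=O)c1ccccc1`, was tested in an ADME assay on HepG2 cells (Homo sapiens) for cytotoxicity, read by CellTiter-Glo and resazurin assay, with a stated time of 72 h (on this read-out lower numbers stand for an effect already at smaller amounts and higher numbers for an effect only at larger amounts of compound), and in this assay compound 1 gives > 26000 nM, which is a limit of the assay rather than a number. Compound 2, `CCCNCc1ccccc1OCCCCCC(=O)OCC`, gives in this assay > 26000 nM, again a limit of the assay and not a number. Neither compound therefore has a measured value; both sit at the same boundary, as shown by the limit of > 26000 nM in this assay, at which 2 of the 2 values shown sit, and no step between measured compounds can be drawn from them.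

Compound 3, `CCOC(=O)CCCCCOc1ccccc1C=O`, has not yet been measured in this assay. It differs from compound 2 in one place: formyl in place of (propylamino)methyl on an aromatic carbon. With both measured compounds resting at the limit, there is nothing to suggest a step beyond the scatter in either direction, and the expectation is that compound 3 will also be reported at or beyond the same limit.

The estimated step is a step that the limit leaves unreadable from compound 2 to compound 3, which is expected to be none beyond the scatter. For compound 3 the expected value in this assay is 40000 nM, with a range from 15000 nM to 120000 nM, most likely again only as a limit.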

Compound 3, half-maximal effective concentration: > 26000 nM
Compound 3: no number, only a limit (the forecaster's own chance of this, stated with the estimate: 75%); the middle value lies beyond the limit too.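

In this assay compound 3 gives > 26000 nM as a limit of the assay and not a number. Among the compounds shown here, no step between compound 2 and compound 3 can therefore be read: the limit of > 26000 nM in this assay, at which 3 of the 3 values shown sit. The compounds shown leave open at what concentration, if any, each would show an effect in this assay and whether formyl in place of (propylamino)methyl on an aromatic carbon changes it.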